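A few compounds are considered here, and "the series" means these few. Any claim that something is new, unique, unknown or untested is made for them only; others in the source may bear on it.

Measured compounds:
- compound 1 `O=C(/C=C/c1coc2cc(O)ccc2c1=O)NCc1ccc(F)cc1`: > 100000 nM
- compound 2 `COc1ccc2c(=O)c(/C=C/C(=O)Nc3cccc(Cl)c3)coc2c1`: 470 nM

In a functional assay on A549 cells (Homo sapiens) for inhibition, read by MTT assay, with a stated time of 48 h (on this read-out higher numbers stand for weaker inhibition and lower numbers for stronger inhibition), compound 1 gives > 100000 nM, which is a limit of the assay and not a number; that is the limit of > 100000 nM in this assay, at which 1 of the 2 values shown sits. In this assay, for the measured compounds named here, compound 2 gives 470 nM and so holds the only numerical value shown. Compound 3 `COc1ccc2c(=O)c(/C=C/C(=O)Nc3ccc(C)cc3)coc2c1` is not yet measured. It differs from compound 2 by 4-methylphenyl in place of 3-chlorophenyl on an amide-type nitrogen. Going by the values given here, no measured step covers this change, so the expected step of a 1.5-fold higher number from compound 2 to compound 3 (0.17 log units; within the scatter) is small, within the usual scatter, with at most a slight loss. Compound 3 is estimated at 700 nM, between 250 nM and 2500 nM.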

Compound 3, half-maximal inhibitory concentration: 17500 nM
Estimate against measurement, compound 3: 25-fold (1.40 log units) below; measured number above the stated range.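

Under this assay the change from 3-chlorophenyl to 4-methylphenyl on the amide-type nitrogen gives a 37-fold higher number from compound 2 to compound 3 (1.57 log units; beyond the scatter) and so marks this aryl group as a place where a single change moves the read-out strongly. Both groups count the same heavy atoms and one carbon-only aromatic ring, so these counts do not separate compound 2 from compound 3. No measured property here accounts for the step.

The swap alters the substituent and its ring position together, so their shares stay unresolved. 3-Methylphenyl and 4-chlorophenyl would separate them.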